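The source may report more compounds than this note shows. Statements on the series, on what has been measured and on what is new or still open speak of the compounds shown alone.

Of the compounds shown here, three have so far been measured in a functional assay on MCF-10A cells (Homo sapiens) for inhibition; a lower number here means a stronger inhibitor, a higher number a weaker inhibitor. Compound 1 `O=C(/C=C/c1ccc(B(O)O)cc1)c1ccc[nH]1` gives 38000 nM, compound 2 `O=C(/C=C/c1ccc(F)c(Cl)c1)c1ccc(B(O)O)cc1` gives 25000 nM, and compound 3 `O=C(/C=C/c1ccc(I)cc1)c1ccc(O)cc1` gives 15000 nM. Compound 3 stands within the scatter of compound 2, while its number lies below that of compound 1 by a gap beyond the scatter.

The next compound to be tested is compound 4 `O=C(/C=C/c1ccc(I)cc1)c1ccc(B(O)O)cc1`, which differs from compound 3 in one place. The hydroxy on an aromatic carbon of a six-membered aromatic ring of carbon only, para to a large group, gives way to a group of 3 heavy atoms (1 boron, 2 oxygen; no ring): a group of 3 heavy atoms (1 boron, 2 oxygen; no ring) in place of one oxygen atom, on an aromatic carbon.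

For the measured compounds named here, no pair of measured compounds isolates this change, so the data give no direct size for it. The entering group is already present in compound 2 at 25000 nM, a value within the scatter of compound 3, and it is also present in compound 1 at 38000 nM. No step beyond the scatter is therefore expected in this assay, and any direction is only tentative. The expected change is a 1.3-fold higher number from compound 3 to compound 4 (0.12 log units; within the scatter). Compound 4 is estimated at 20000 nM, with an expected range from 8000 nM to 50000 nM.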

Compound 4, half-maximal inhibitory concentration: 75000 nM
Beside the measured number, compound 4's estimate is 3.8-fold (0.57 log units) below it, and the stated range ends below it.
By their numbers in this assay, from the lowest: compounds 3, 2, 1 and 4 (each within the scatter of the next, the first and the last beyond it).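

At this place, on an aromatic carbon of a six-membered aromatic ring of carbon only and para to a large group, the change has a measurable size in this assay: exchanging the hydroxy for the group of 3 heavy atoms (1 boron, 2 oxygen; no ring) gives a 5.0-fold higher number from compound 3 to compound 4 (0.70 log units; beyond the scatter), a step beyond the scatter. For the compounds shown here, it is the first single-place step available here, and it shows that inhibition responds to what sits at this position, with the hydroxy giving the stronger inhibitor of the two on this core, something that the presence of the entering group in compound 1 and compound 2 could not reveal. Nothing available accounts for this step.

As far as these compounds go, with only these two groups seen at this place, it remains open whether an amine, a carboxylic acid or a methoxy group would give a number nearer that of compound 3 or that of compound 4. It is also open whether the same exchange would give a step of similar size on the cores of compound 1 and compound 2, for which no hydroxy counterpart is shown.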